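The source may hold more compounds than are shown below. What is called first, only, known or untested is meant among the compounds shown, and "the series" means these compounds.

Compound 1 `CCC1(Cc2ccccc2)OS(=O)(=O)C=C1OCC#N`: > 400000 nM
Compound 2 `CC1(C(c2ccccc2)c2ccccc2)OS(=O)(=O)C=C1OCc1ccccc1`: >= 400000 nM
Compound 3 `CCC1(Cc2ccccc2)OS(=O)(=O)C=C1OC(c1ccccc1)c1ccccc1`: >= 80000 nM

These three compounds share one core and were all tested in an ADME assay on HEL cells (Homo sapiens) for cytotoxicity, with a stated time of 3 days; a lower number here means that less compound is tolerated, a higher number that more compound is tolerated. For compound 1 the value > 400000 nM is a limit of the assay and not a number. For compound 2 the value >= 400000 nM is also a limit. For compound 3 the value >= 80000 nM is a limit as well. Among the measured compounds shown here, since every value is a limit, no step between the measured compounds can be sized, and compound 1 simply stands at the limit (the limit of > 400000 nM in this assay, at which 1 of the 3 values shown sits).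

Compound 4 `C=CCOC1=CS(=O)(=O)OC1(CC)Cc1ccccc1` has not been measured yet. It differs from compound 1 in one place: vinyl in place of cyano on a saturated chain carbon bound to an oxygen on an unsaturated carbon. For the measured compounds named here, no measured step shows what such a change does in this assay. The expectation is that compound 4 is tolerated much like compound 1, so the step of a number no higher from compound 1 to compound 4 (the limit leaves the size open) is expected to be none beyond the scatter. Compound 4 is therefore expected to give about 400000 nM, within a range from 80000 nM to 400000 nM, most likely reported again as a limit.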

Compound 4, minimum cytotoxic concentration: 80000 nM
The estimate for compound 4 lay 5.0-fold (0.70 log units) above the measured number; the measured number falls inside the stated range.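

In this assay, vinyl in place of cyano on a saturated chain carbon bound to an oxygen on an unsaturated carbon gives an at least 5.0-fold lower number from compound 1 to compound 4 (0.69 log units; beyond the scatter) and so shows that the group at this place matters for how much compound the cells tolerate. Compound 4 with 80000 nM is the only compound shown whose value is a number and not a limit, which gives the series its first fixed point. As far as these compounds go, the full size of the step stays open because compound 1 sits at a limit of the assay: the limit of > 400000 nM in this assay, at which 1 of the 4 values shown sits.

From the compounds shown here alone, whether the lower number comes from the vinyl group itself or from the loss of the nitrile remains open, as only these two groups can be compared here. Going by these compounds, how an amine, a carboxylic acid or a longer chain would read at this place also remains open.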